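Half-life after swapping the group on compound 1

The compounds below may be only part of what the source reports. "The series", "measured", "known", "first", "only" and "open" are said of these compounds alone.

Measured in an ADME assay on a cell-free system (plasma, Mus musculus, strain CD-1) for metabolic stability, read by LC-MS, tested at 1 uM; on this read-out lower numbers stand for a shorter-lived compound and higher numbers for a longer-lived compound:
Compound 1 `Cn1nc(-c2ccc(NC(=O)CCc3nc4ccccc4c(=O)[nH]3)cc2)c2ccccc21`: > 16.6 h, a limit and not a number
Compound 2 `COc1ccccc1NC(=O)c1ccc(NC(=O)CCc2nc3ccccc3c(=O)[nH]2)cc1C`: 0.717 h
Compound 3 `COc1ccccc1N(C)C(=O)c1ccc(NC(=O)CCc2nc3ccccc3c(=O)[nH]2)cc1`: 0.633 h

Compound 1 stands at the limit of > 16.6 h in this assay, at which 1 of the 3 values shown sits. This value is a limit of the assay, so the true half-life of compound 1 is not given as a number. The two other compounds carry numbers, and these are far shorter.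

Compound 4 `O=C(CCc1nc2ccccc2c(=O)[nH]1)Nc1ccc(-c2c[nH]c(-c3ccccc3)n2)cc1` has not yet been measured in this assay. It differs from compound 1 at one place, an aromatic carbon para to a large group, where the 1-methyl-1H-indazol-3-yl group leaves: a group of 11 heavy atoms (9 carbon, 2 nitrogen; one five-membered aromatic ring with 2 hetero atoms, one six-membered aromatic ring of carbon only) in place of a group of 10 heavy atoms (8 carbon, 2 nitrogen; one five-membered aromatic ring with 2 hetero atoms, one six-membered aromatic ring of carbon only), on an aromatic carbon. Going by the values given here, no pair of measured compounds differs in one place, so no measured step gives the size of this change.

The expectation leans on compound 1 and its limit of > 16.6 h, as the entering group has the same kinds of ring as the one leaving. The expected step of an at least 2.0-fold lower number from compound 1 to compound 4 (0.31 log units; beyond the scatter) is of moderate size, toward a shorter half-life. The low end of the range allows for the short values of the other compounds. Compound 4 is estimated at 8 h, with an expected range of 2 h to 30 h.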

Compound 4, half-life: 0.883 h
The estimate for compound 4 lay 9.1-fold (0.96 log units) above the measured number; the whole stated range lies above it.
By their numbers in this assay, from the lowest: compounds 3, 2 and 4 (each within the scatter of the next). At a limit, above all of these: compound 1.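

In this assay, the exchange on this aromatic carbon para to a large group gives an at least 18-fold lower number from compound 1 to compound 4 (1.27 log units; beyond the scatter), the only step shown that measures the effect of a change at this position. The 1-methyl-1H-indazol-3-yl group and the group that enters have the same kinds of ring, one five-membered aromatic ring with 2 hetero atoms and one six-membered aromatic ring of carbon only, so sharing these ring kinds does not keep the half-life of compound 4 near that of compound 1, although the two groups differ in their counts of heavy atoms, hydrogen-bond donors and hydrogen-bond acceptors. The size of the step is only a bound, set by the value of compound 1, which is a limit and not a number: the limit of > 16.6 h in this assay, at which 1 of the 4 values shown sits.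

On these data alone, whether the hydrogen-bond donor of the entering group goes with the shorter half-life stays open, and a methyl group on the nitrogen of its five-membered ring would be the one-place change that could speak to this. Also open, as far as these compounds go, are the true half-life of compound 1 and the result of a much smaller group, such as an amine, on this aromatic carbon.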